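From 4-Methylphenyl to 3-Chlorophenyl: an Expected Potency Shift

A few compounds are considered here, and "the series" means these few. Any claim that something is new, unique, unknown or untested is made for them only; others in the source may bear on it.

Measured compounds:
compound 1 `COc1ccc(-c2cc(C(C)(C)C)cc(C(C)C)c2CO)cc1` gives 1300 nM
compound 2 `CC(C)c1cc(C(C)(C)C)cc(-c2ccc(-c3ccccc3)cc2)c1CO` gives 680 nM
compound 3 `Cc1ccc(-c2cc(C(C)(C)C)cc(C(C)C)c2CO)cc1` gives 300 nM

These values come from a functional assay on RKE cells for antagonist activity at Vasoactive intestinal polypeptide receptor 1 (Rattus norvegicus), read by HTRF and cAMP accumulation, with stated times of 10 min and 30 min; on this read-out lower numbers stand for stronger inhibition and higher numbers for weaker inhibition. Compound 3 stands lowest of the three: compound 2 lies nearest, and compound 1 furthest, both with higher numbers beyond the scatter. The steps seen so far all swap the group on the outer ring: a 4.3-fold lower number from compound 1 to compound 3 (0.64 log units; beyond the scatter), a 2.3-fold lower number from compound 2 to compound 3 (0.36 log units; beyond the scatter) and a 1.9-fold lower number from compound 1 to compound 2 (0.28 log units; within the scatter). Compound 4 `CC(C)c1cc(C(C)(C)C)cc(-c2cccc(Cl)c2)c1CO` makes a different kind of change, (3-chlorophenyl in place of 4-methylphenyl on an aromatic carbon). Within the data shown here, no measured step exchanges a 4-methylphenyl for a 3-chlorophenyl, so the earlier steps give only a sense of scale: changes at this ring moved the number by modest amounts, and the methyl of compound 3 gave the lowest value. The expectation is therefore a modest step toward a higher number, a 2.0-fold higher number from compound 3 to compound 4 (0.30 log units; within the scatter), with a wide range. Compound 4 is estimated at 600 nM, between 200 nM and 2000 nM.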

Compound 4, half-maximal inhibitory concentration: 100 nM
Estimate against measurement, compound 4: 6.0-fold (0.78 log units) above, outside the stated range (below it).
By their numbers in this assay, from the lowest: compound 4; then compound 3; then compounds 2 and 1 (each within the scatter of the next).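

In this assay, 3-chlorophenyl in place of 4-methylphenyl gives a 3.0-fold lower number from compound 3 to compound 4 (0.48 log units; beyond the scatter), so the aromatic carbon ortho to a hydroxymethyl group can carry a group that gives a lower number than any of the earlier three. The two groups hold the same number of heavy atoms, and neither has a hydrogen-bond donor or acceptor, so this lower number comes without any larger group or any added donor or acceptor. Nothing here offers a measured explanation for the shift.

This change replaces methyl with chlorine and also moves the substituent around the outer ring, so the compounds shown cannot separate those two differences. A matched pair with 4-chlorophenyl and 3-methylphenyl at the same carbon would pull them apart, while 3-aminophenyl would test an amine there.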